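A few compounds are considered here, and "the series" means these few. Any claim that something is new, unique, unknown or untested is made for them only; others in the source may bear on it.

So far, three compounds have been tested in a functional assay (aorta) for inhibition, with Rattus norvegicus as the target (on this read-out higher numbers stand for weaker inhibition and lower numbers for stronger inhibition), and give clearly separated numbers. Here compound 1 (`C/N=C(\S)[C@]1(c2ccncc2)CCCC[S+]1[O-]`) reads 25000 nM and compound 2 (`C/N=C(\S)[C@]1(c2cccc(C#N)c2)CCCC[S+]1[O-]`) reads 1600 nM on the same scale. Compound 3 (`CCC/N=C(\S)[C@]1(c2cccnc2)CCCC[S+]1[O-]`) reads 600 nM and holds the lowest number of the three, which means the strongest inhibition. Compound 2 is its nearest neighbour and compound 1 lies furthest away, with both gaps beyond the usual scatter. These three compounds differ from one another in more than one place, so no single structural change can be read from them.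

Compound 4 (`O=C(O)CC/N=C(\S)[C@]1(c2cccnc2)CCCC[S+]1[O-]`) differs from compound 3 in one place (carboxy in place of methyl on a saturated chain carbon, two bonds along the chain from a double-bonded nitrogen). It has carboxy in place of methyl on a saturated chain carbon, two bonds along the chain from a double-bonded nitrogen, which turns propyl to 2-carboxyethyl. Within the data shown here, no measured pair shows this change, so the expectation is a loose judgement. In this assay a sizeable move towards a higher number, beyond the scatter, is expected, and that would mean weaker inhibition. The estimated change is a 13-fold higher number from compound 3 to compound 4 (1.12 log units; beyond the scatter) overall. For compound 4 the estimated value is 8000 nM, with the expected range running from 1500 nM to 40000 nM as its likely span.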

Compound 4, concentration for 90% inhibition: > 30000 nM
Compound 4: only a limit was reported; the forecaster's own chance of this, stated with the estimate: 10%; middle value at least 3.7-fold (0.57 log units) away from the limit.
By their numbers in this assay, from the lowest: compound 3; then compound 2; then compound 1. At a limit, above all of these: compound 4.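

In this assay, among these compounds, changing propyl to 2-carboxyethyl on the shared core gives an at least 50-fold higher number from compound 3 to compound 4 (1.69 log units; beyond the scatter), and this is the first step in the set that comes from a change in one place only. Compound 4 gives > 30000 nM, which is a limit and not a number, so the step gives only a minimum size: the limit of > 30000 nM in this assay, at which 1 of the 4 values shown sits. The chain on the double-bonded nitrogen is thus a place where one change can cost a large part of the inhibition, something the three earlier compounds could not show, as they differ from one another in more than one place.

This single pair does not tell whether the loss comes from the carboxy group itself or would follow from other groups at the end of this chain, and it gives no reason for the loss. An amine, an alcohol or an amide at the same place, or a carboxylic acid on a longer chain, would show how far the result reaches beyond this one group.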